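This account rests on a few compounds, and the source may have more. Where it says the series, first, only, none or still open, it means among the compounds named here.

Measured in a functional assay on U-251 cells (Homo sapiens) for cytotoxicity; on this read-out higher numbers stand for weaker inhibition of growth and lower numbers for stronger inhibition of growth:

Compound 1 `COc1ccc(C2=C(c3ccc(SC)cc3)CC3CCCN3C2=O)cc1OC(=O)CNC(=O)OC(C)(C)C`: 6000 nM
Compound 2 `CSc1ccc(C2=C(c3ccc(F)c(C)c3)C(=O)N3CCCC3C2)cc1`: 200 nM
Compound 3 `COc1ccc(C2=C(c3ccc(SC)cc3)CC3CCCN3C2=O)cc1`: 2000 nM

Compound 3 holds the middle place among these three numbers. Its value lies beyond the scatter from both neighbours, with compound 1 on the higher side and compound 2 on the lower side.

Compound 4 `CSc1ccc(C2=C(c3ccc(F)cc3)C(=O)N3CCCC3C2)cc1` departs from compound 3 by a single change, fluoro in place of methoxy on an aromatic carbon, para to a large group.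

Two measured steps are available. The one that bears most directly is a 10-fold higher number from compound 2 to compound 3 (1.00 log units; beyond the scatter), in which 4-methoxyphenyl came in at the same place, replacing a ring that carries fluoro and also a methyl. The other, a 3.0-fold lower number from compound 1 to compound 3 (0.48 log units; beyond the scatter), changes a different place on the same ring and so says little here. Leaving 4-methoxyphenyl should therefore lower the number in this assay. For the measured compounds named here, since no methyl comes in, only part of the larger step is expected to return, though no measured pair separates the two substituents. The expected change is a 5.0-fold lower number from compound 3 to compound 4 (0.70 log units; beyond the scatter).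

For compound 4 the estimated value is 400 nM, with an expected range from 130 nM to 1200 nM.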

Compound 4, concentration for 50% growth inhibition: 90 nM
For compound 4 the middle estimate is 4.4-fold (0.65 log units) above the measured one, and the stated range ends above it.
By their numbers in this assay, from the lowest: compound 4; then compound 2; then compound 3; then compound 1.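

In this assay, the change from 4-methoxyphenyl to 4-fluorophenyl alone gives a 22-fold lower number from compound 3 to compound 4 (1.35 log units; beyond the scatter), a larger step than a 10-fold higher number from compound 2 to compound 3 (1.00 log units; beyond the scatter), so the earlier step had understated what leaving methoxy for fluoro does at this position. The methyl of compound 2 also turns out not to help on this read-out, as hydrogen in its place gives a 2.2-fold lower number from compound 2 to compound 4 (0.35 log units; beyond the scatter), a modest step but one beyond the scatter. Nothing shown here accounts for either step.

The compounds shown leave open whether the lower number belongs to fluoro itself or simply to the loss of methoxy: hydrogen, chloro or an amine at this same place on the ring would separate those two readings. As far as these compounds go, it also remains open whether the step would hold with a longer chain such as ethoxy, or with a hydroxyl group, in place of fluoro on this aromatic carbon.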